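The compounds below may be only part of what the source reports. "The series", "measured", "known", "first", "only" and "open" are said of these compounds alone.

In a functional assay on DA-3 cells for cytotoxicity against DA-3 cell line (Mus musculus), read by MTT assay (on this read-out higher numbers stand for weaker inhibition and lower numbers for stronger inhibition), compound 1 `CC(=O)O[C@@H]1OC(=O)[C@](C)(C(C)=O)[C@@H]1C` gives 7000 nM, and compound 2 `CC(=O)O[C@@H]1OC(=O)[C@](Cc2ccccc2)(C(C)=O)[C@@H]1C` gives 45000 nM, so that a 6.4-fold higher number from compound 1 to compound 2 (0.81 log units; beyond the scatter). Compound 3 `CC(=O)O[C@@H]1OC(=O)[C@@](C)(C(C)=O)[C@@H]1C` gives 9000 nM; its pair with compound 1 rests on (the fact that compounds 1 and 3 differ only in the configuration as drawn), and a 1.3-fold higher number from compound 1 to compound 3 (0.11 log units; within the scatter). Among the three numbers compound 3 stands second highest: compound 1 lies nearest, within the scatter, and compound 2 lies furthest, beyond it. Compound 4 `CC(=O)O[C@@H]1OC(=O)[C@@](Cc2ccccc2)(C(C)=O)[C@@H]1C` differs from compound 3 by phenyl in place of hydrogen on a saturated chain carbon bound to a saturated ring carbon. Within the data shown here, the only measured step with the same change is the one from compound 1 to compound 2, a modest weakening beyond the scatter, so a step of like size and direction is expected here: a 5.0-fold higher number from compound 3 to compound 4 (0.70 log units; beyond the scatter). Compound 4 is therefore estimated at 45000 nM, most likely between 15000 nM and 130000 nM.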

Compound 4, half-maximal inhibitory concentration: 44000 nM
Compound 4: the middle estimate sits 1.0-fold (0.01 log units) above what was measured; the range from low to high includes it.
By their numbers in this assay, from the lowest: compounds 1 and 3 (each within the scatter of the next); then compounds 4 and 2 (each within the scatter of the next).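

Methyl to benzyl now gives a 4.9-fold higher number from compound 3 to compound 4 (0.69 log units; beyond the scatter) in this assay, so the weakening seen on one configuration of the stereocentre also appears on the other, with steps of similar size: the same change on two cores in this assay, a 6.4-fold higher number (0.81 log units; beyond the scatter) from compound 1 to compound 2 and a 4.9-fold higher number (0.69 log units; beyond the scatter) from compound 3 to compound 4, 1.3-fold (0.12 log units) apart, within the scatter of two such steps. With benzyl in place, drawing the stereocentre either way keeps the numbers within the scatter, a 1.0-fold lower number from compound 2 to compound 4 (0.01 log units; within the scatter), as with methyl: the fact that compounds 2 and 4 differ only in the configuration as drawn.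

On these data alone, whether a carboxylic acid, an amine or a longer chain without the phenyl ring would also weaken the effect at this position remains open. So does whether any group here would strengthen it.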